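Swapping a phenylalkyl chain for a cyclopropyl ester

The source may hold more compounds than are shown below. What is called first, only, known or untested is meant among the compounds shown, and "the series" means these compounds.

Compound 1 `O=C(CCCCOc1ccccc1)OCC1COCCOCCOCCOCCOCCO1`: in a functional assay on HeLa cells (Homo sapiens) for inhibition, read by sulforhodamine B assay, with a stated time of 48 h (on this read-out lower numbers stand for stronger inhibition of growth and higher numbers for weaker inhibition of growth), compound 1 gives > 100000 nM, which is a limit of the assay and not a number.
Compound 2 `O=C(CCCCCc1ccccc1)OCC1COCCOCCOCCOCCOCCO1`: in this assay compound 2 gives 79000 nM.
Compound 3 `O=C(OCC1COCCOCCOCCOCCOCCO1)c1cccc(-c2ccc(Br)cc2)c1`: in this assay compound 3 gives 7800 nM.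

Of the two numbers shown, compound 2 holds the higher one; compound 3 sits lower, and that gap lies beyond the scatter. Among the measured compounds shown here, the one step measured between neighbouring structures, an at least 1.2-fold lower number from compound 1 to compound 2 (0.10 log units; that floor lies within the scatter), runs from a limit and stays within the scatter, so it tells little about how far the ester side chain can be altered.

For the measured compounds named here, compound 4 `CC(C)=CC1C(C(=O)OCC2COCCOCCOCCOCCOCCO2)C1(C)C` takes the shared core of compound 2 in a different direction. 2,2-dimethyl-3-(2-methylprop-1-en-1-yl)cyclopropyl in place of 5-phenylpentyl on a carbonyl carbon This change removes the aromatic ring of compound 2 altogether and is not covered by any measured step; compound 3, the only other numbered compound, keeps an aromatic ester and differs in several places at once. Without a bearing step, no shift beyond the scatter is expected in either direction, though wide uncertainty remains, and a further limit is possible.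

Compound 4 is therefore estimated at 80000 nM, with a range from 20000 nM to 300000 nM, meaning an expected step of a 1.0-fold higher number from compound 2 to compound 4 (0.01 log units; within the scatter).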

Compound 4, concentration for 50% growth inhibition: 63000 nM
For compound 4 the middle estimate is 1.3-fold (0.10 log units) above the measured one; measured number inside the range.
By their numbers in this assay, from the lowest: compound 3; then compounds 4 and 2 (each within the scatter of the next). At a limit, above all of these: compound 1.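

Placing 2,2-dimethyl-3-(2-methylprop-1-en-1-yl)cyclopropyl in place of 5-phenylpentyl on a carbonyl carbon gives a 1.3-fold lower number from compound 2 to compound 4 (0.10 log units; within the scatter) in this assay, the first measured change at this position that removes the six-membered aromatic ring altogether. The chain can therefore lose that ring and take a three-membered ring and a double bond outside aromatic rings without the number leaving the scatter, so the aromatic ring of compound 2 is not required to keep growth inhibition at this weak level in this assay. The step against the phenoxy chain, an at least 1.5-fold lower number from compound 1 to compound 4 (0.20 log units; that floor lies within the scatter), adds little, as it gives only a floor and runs from a value that is a limit of the assay and not a number: the limit of > 100000 nM in this assay, at which 1 of the 4 values shown sits.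

Compound 3, at 7800 nM, differs from compound 4 in more than one place, so what sets its value apart remains unresolved by these compounds. The compounds shown also leave open how the number would respond to an amine or a carboxylic acid at the end of the ester side chain, or to a longer chain at the same carbonyl carbon.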